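A few compounds are considered here, and "the series" means these few. Any claim that something is new, unique, unknown or untested is made for them only; others in the source may bear on it.

Two compounds of this series have numbers in an assay on isolated protein for inhibition of proto-oncogene tyrosine-protein kinase receptor Ret variant V804M (Homo sapiens), read by 33P incorporation, with stated times of 15 min and 40 min; a higher number here means a weaker inhibitor, a lower number a stronger inhibitor. Compound 1 `O=C(Nc1ccc(Br)cc1)Nc1ccc(Nc2ncnc3c2OCCN3)cc1` gives 2350 nM; compound 2 `COc1ccc(NC(=O)Nc2ccc(Nc3ncnc4c3OCCN4)cc2)cc1` gives 824 nM. Among the compounds with values here, the single measured step, a 2.9-fold lower number from compound 1 to compound 2 (0.46 log units; beyond the scatter), is the only change recorded so far. Compound 2 therefore holds the lowest of the two numbers, with compound 1 the nearest and higher.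

Compound 3 `COc1cccc(NC(=O)Nc2ccc(Nc3ncnc4c3OCCN4)cc2)c1` differs from compound 2 by 3-methoxyphenyl in place of 4-methoxyphenyl on an amide-type nitrogen: the same atoms, joined differently. Within the data shown here, no measured step bears on this kind of change; the step from compound 1 to compound 2 exchanges one substituent for another at the same site and says nothing about relocating the methoxy group within the ring. Among the measured compounds shown here, with no precedent pointing either way, the expectation in this assay is a step within the scatter. Compound 3 is estimated at 900 nM, within a range from 400 nM to 2000 nM. The expected step is a 1.1-fold higher number from compound 2 to compound 3 (0.04 log units; within the scatter).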

Compound 3, half-maximal inhibitory concentration: 5290 nM
Beside the measured number, compound 3's estimate is 5.9-fold (0.77 log units) below it; measured number above the stated range.
By their numbers in this assay, from the lowest: compound 2; then compound 1; then compound 3.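

In this assay the place of the methoxy on the ring proves to matter at this amide-type nitrogen: 3-methoxyphenyl in place of 4-methoxyphenyl, with the same atoms, gives a 6.4-fold higher number from compound 2 to compound 3 (0.81 log units; beyond the scatter) and is a larger change than the exchange of bromo for methoxy. The gain seen with methoxy over bromo therefore holds only for 4-methoxyphenyl, since 3-methoxyphenyl in place of 4-bromophenyl runs the other way, with a 2.3-fold higher number from compound 1 to compound 3 (0.35 log units; beyond the scatter) in the same assay. Nothing available explains this dependence on ring position.

Bromo appears here only as 4-bromophenyl, so it remains open whether moving another substituent shifts the number in the same direction. As far as these compounds go, an unsubstituted phenyl, which would show how each substituted ring compares with none, and an amine or a hydroxy group in place of the methoxy also remain open.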